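Adding a fluorine to the core of compound 3

The source may report more compounds than this note shows. Statements on the series, on what has been measured and on what is new or still open speak of the compounds shown alone.

Compound 1 `Cc1cc2nc(-c3cn(-c4ccccc4)nc3-c3ccccc3)[nH]c2cc1C` is the reference point of this small set. In a functional assay on A549 cells (Homo sapiens) for antiproliferative activity, read by MTT assay, with a stated time of 48 h (on this read-out higher numbers stand for weaker inhibition and lower numbers for stronger inhibition), compound 1 gives 14500 nM. Compound 2 `Cc1cc2nc(-c3cn(-c4ccccc4)nc3-c3ccc(F)cc3)[nH]c2cc1C` differs from it by one change: fluoro in place of hydrogen on an aromatic carbon. Compound 2 reaches only a limit in this assay, reported as > 50000 nM. That limit is described by the limit of > 50000 nM in this assay, at which 1 of the 3 values shown sits. The step is therefore an at least 3.4-fold higher number from compound 1 to compound 2 (0.53 log units; beyond the scatter), a weakening of inhibition.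

Compound 3 `Clc1ccc(-c2nn(-c3ccccc3)cc2-c2nc3ccccc3[nH]2)cc1` carries a different core; the difference between the two cores is not broken down here. In this assay compound 3 gives 5960 nM, the lowest of the two numbers measured and beyond the scatter from compound 1.

Compound 4 `Fc1ccc2[nH]c(-c3cn(-c4ccccc4)nc3-c3ccc(Cl)cc3)nc2c1` has not yet been measured. It differs from compound 3 by fluoro in place of hydrogen on an aromatic carbon. The place is not the same as before: in compound 2 the fluorine sits on a six-membered aromatic ring of carbon only, para to a large group, whereas in compound 4 it sits on a six-membered aromatic ring of carbon only that is part of a fused or bridged system of two rings, meta to a fused ring and para to a fused ring. It is the same kind of change, not the same change.

Given that the only measured instance, an at least 3.4-fold higher number from compound 1 to compound 2 (0.53 log units; beyond the scatter), weakened inhibition, compound 4 is expected to give a somewhat higher number than compound 3, but with wide uncertainty because the place differs. The expected step is a 1.7-fold higher number from compound 3 to compound 4 (0.22 log units; within the scatter). Compound 4 is estimated at 10000 nM, between 3000 nM and 35000 nM.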

Compound 4, half-maximal inhibitory concentration: 4610 nM
Compound 4: middle estimate off by 2.2-fold (0.34 log units), on the high side; low and high end bracket the measured number.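

In this assay, putting fluoro in place of hydrogen on the fused ring system of compound 3 gives a 1.3-fold lower number from compound 3 to compound 4 (0.11 log units; within the scatter), so at this place on this core the change leaves the number unmoved within the usual scatter. Set beside the earlier step, this shows that the same kind of change does not carry over with the same outcome from one core to the other in this series: the same change on two cores in this assay, an at least 3.4-fold higher number (0.53 log units; beyond the scatter) from compound 1 to compound 2 and a 1.3-fold lower number (0.11 log units; within the scatter) from compound 3 to compound 4, at least 4.4-fold (0.64 log units) apart, beyond the scatter of two such steps. As far as these compounds go, what it does not show is whether the core or the place of the fluorine sets that gap, as the two pairs differ in both, and the size of the earlier step stays open as well, since compound 2 stands at a limit and not at a number: the limit of > 50000 nM in this assay, at which 1 of the 4 values shown sits.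

The compounds shown leave open how fluoro at one place compares with fluoro at the other when the core is held the same. They also leave open whether a methoxy group or an amine at the place taken by fluoro in compound 4 would likewise leave the number within the scatter of compound 3.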